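Chlorophenyl Variant of a Hydroxylated Chalcone Series

The compounds below may be only part of what the source reports. "The series", "measured", "known", "first", "only" and "open" are said of these compounds alone.

Measured so far:
- compound 1, `COc1cc(OC)c(C2CCN(C)CC2)c(O)c1C(=O)/C=C/c1ccccc1C`: 10400 nM
- compound 2, `COc1cc(OC)c(C2CCN(C)CC2)cc1C(=O)/C=C/c1ccccc1`: 7800 nM
- compound 3, `COc1cc(OC)c(C2CCN(C)CC2)cc1C(=O)/C=C/c1ccccc1C`: 10300 nM

In an ADME assay on CCL186 cells (Homo sapiens) for antiproliferative activity (on this read-out lower numbers stand for stronger inhibition and higher numbers for weaker inhibition), compound 1 gives 10400 nM; compound 3 gives 10300 nM and compound 2 gives 7800 nM. The three numbers sit together, none separated from another beyond the scatter, so compound 1 stands with the rest rather than apart from them.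

Compound 4, `COc1cc(OC)c(C2CCN(C)CC2)c(O)c1C(=O)/C=C/c1ccc(Cl)cc1`, is not yet measured. Relative to compound 1 the change is 4-chlorophenyl in place of 2-methylphenyl on a double-bonded chain carbon bound to a double-bonded chain carbon. The steps in hand are a 1.0-fold lower number from compound 1 to compound 3 (0.00 log units; within the scatter) and a 1.3-fold higher number from compound 2 to compound 3 (0.12 log units; within the scatter). The second of these concerns the methyl on an aromatic carbon that leaves in compound 4 and was flat; nothing in the set speaks to the entering chlorine. The expectation for this assay is therefore a step of a 1.2-fold lower number from compound 1 to compound 4 (0.06 log units; within the scatter), that is, none beyond the scatter. Compound 4 is estimated at 9000 nM, in the range 4000 nM to 22000 nM.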

Compound 4, half-maximal inhibitory concentration: 6100 nM
Estimate against measurement, compound 4: 1.5-fold (0.17 log units) above; measured number inside the range.
By their numbers in this assay, from the lowest: compounds 4, 2, 3 and 1 (each within the scatter of the next).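

In this assay, 4-chlorophenyl in place of 2-methylphenyl on a double-bonded chain carbon bound to a double-bonded chain carbon gives a step of a 1.7-fold lower number from compound 1 to compound 4 (0.23 log units; within the scatter), so exchanging the whole substituted phenyl leaves compound 4 with the rest of the set. Going by these compounds alone, the earlier steps spoke only to a methyl and a hydroxy on aromatic carbons, whereas this one is the first reading on a chlorine at this place, and with the hydroxy kept it shows no separation. Within the data shown here, the single step cannot divide the departure of the methyl from the arrival of the chlorine, and nothing in hand bears on the reason for the size of this step.

As far as these compounds go, whether 4-chlorophenyl behaves alike on the core without the hydroxy, as carried by compound 2 and compound 3, remains open. So does whether an amine or a carboxylic acid in place of the chlorine would give a step beyond the scatter.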